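The source may hold more compounds than are shown below. What is called first, only, known or untested is meant among the compounds shown, and "the series" means these compounds.

Compound 3 `O=C(Nc1ccc(-n2ccc3c(NC(=O)c4ccccc4)nccc32)cc1)Nc1ccc(Cl)c(C(F)(F)F)c1` gives the lowest of the two numbers in a functional assay on A-375 cells (Homo sapiens) for antiproliferative activity, read by MTT assay, with a stated time of 48 h, in the presence of a further agent that is not named here (a higher number here means a weaker inhibitor, a lower number a stronger inhibitor), namely 2400 nM. Compound 2 `O=C(Nc1ccc(-n2ccc3c(NC(=O)c4ccccc4)nccc32)cc1)Nc1cccc(C(F)(F)F)c1` gives 7000 nM in this assay. Compound 1 `O=C(Nc1ccc(-n2ccc3c(NC(=O)c4ccccc4)nccc32)cc1)Nc1cccc(Cl)c1Cl` reaches only the limit of > 10000 nM in this assay, which is a limit and not a number (the limit of > 10000 nM in this assay, at which 1 of the 3 values shown sits). The step to compound 4 `CCN1CCN(Cc2ccc(NC(=O)Nc3ccc(-n4ccc5c(NC(=O)c6ccccc6)nccc54)cc3)cc2C(F)(F)F)CC1` is (4-ethylpiperazin-1-yl)methyl in place of chloro on an aromatic carbon. Within the data shown here, no measured step swaps a chloro for such a group; the nearest is a 2.9-fold lower number from compound 2 to compound 3 (0.46 log units; beyond the scatter), where the chloro entered, and an at least 4.1-fold lower number from compound 1 to compound 3 (0.61 log units; beyond the scatter), both modest. As far as these compounds go, removing that chloro may undo part of the gain, while the entering group is untested here. Compound 4 is therefore expected to show a 1.0-fold higher number from compound 3 to compound 4 (0.02 log units; within the scatter), giving an estimated 2500 nM with a range of 600 nM to 9000 nM.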

Compound 4, half-maximal inhibitory concentration: 95 nM
Compound 4: the middle estimate sits 26-fold (1.42 log units) above what was measured; the measured number lies below the stated range.
By their numbers in this assay, from the lowest: compound 4; then compound 3; then compound 2. At a limit, above all of these: compound 1.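

Compounds 2 and 3 carry only hydrogen or chloro at this aromatic carbon, ortho to a trifluoromethyl group, whereas (4-ethylpiperazin-1-yl)methyl there gives far larger steps in this assay: a 25-fold lower number from compound 3 to compound 4 (1.40 log units; beyond the scatter), and a 74-fold lower number from compound 2 to compound 4 (1.87 log units; beyond the scatter). The position therefore accepts a much larger group than chloro, and activity improves with it. Nothing measured here explains this gain. The compounds shown cannot separate the contributions of the piperazine ring, its ethyl group and the methylene link. As far as these compounds go, how a morpholine or a simple dimethylamino group would compare at this carbon also remains open.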